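The compounds below may be only part of what the source reports. "The series", "measured", "known", "first", "only" and "open" are said of these compounds alone.

Measured so far:
compound 1 `CN(Cc1ccccc1F)C(=O)C1CCN(C(=O)c2ccc(S(C)(=O)=O)c([N+](=O)[O-])c2)CC1` — > 60000 nM
compound 2 `CN(CC(=O)N1CCN(c2ccc(F)cc2)CC1)C(=O)c1ccc(S(C)(=O)=O)c([N+](=O)[O-])c1` — > 60000 nM

Both compounds were tested in an assay on isolated protein for inhibition of thyroid hormone receptor beta (Homo sapiens), read by fluorescence polarization; on this read-out higher numbers stand for weaker inhibition and lower numbers for stronger inhibition. For compound 1 the result is a limit of the assay, > 60000 nM, not a number. For compound 2 the result is likewise a limit, > 60000 nM. Compound 1 therefore stands at the limit of > 60000 nM in this assay, at which 2 of the 2 values shown sit. Among the measured compounds shown here, no step between measured compounds is available to lean on, and no measured change separates compound 1 from compound 2.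

Compound 3 `CS(=O)(=O)c1ccc(C(=O)N2CCC(C(=O)N3CCc4ccccc4C3)CC2)cc1[N+](=O)[O-]` differs from compound 1 in one place: 1,2,3,4-tetrahydroisoquinolin-2-yl in place of (2-fluorobenzyl)(methyl)amino on a carbonyl carbon. Because both shown values sit at the limit of > 60000 nM in this assay, at which 2 of the 2 values shown sit, no movement beyond the scatter is expected from this change, and the most likely outcome for compound 3 is another limit rather than a number. The estimated step that the limit leaves unreadable from compound 1 to compound 3 is expected to be about none. Compound 3 is expected to give 70000 nM in this assay, with a range from 20000 nM to 200000 nM.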

Compound 3, half-maximal inhibitory concentration: > 60000 nM
Compound 3: no number, only a limit; the forecaster's own chance of this, stated with the estimate: 85%; the middle value lies beyond the limit too.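

Among the compounds shown here, compound 1 and compound 3 each give only a limit of the assay, not a number, so no step between them can be read: the limit of > 60000 nM in this assay, at which 3 of the 3 values shown sit. The compounds shown leave open whether 1,2,3,4-tetrahydroisoquinolin-2-yl changes inhibition at all, and which structure would give a readable number in this assay.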